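Pyridyl isomer swap on the hydrazone series

This account rests on a few compounds, and the source may have more. Where it says the series, first, only, none or still open, it means among the compounds named here.

Measured compounds:
compound 1 `C/C(=N/Nc1nc(-c2ccc(F)cc2)cs1)c1cccs1` — 40%
compound 2 `C/C(=N/Nc1nc(-c2ccc(F)cc2)cs1)c1cccnc1` — 40%

Compound 1 and compound 2 share a core and differ only in the aryl group on the carbon with a double bond to nitrogen. In an in vitro assay on BTI-TN-5B1-4 cells for inhibition of Amine oxidase [flavin-containing] A (Homo sapiens), read by Amplex Red, with a stated time of 15 min, tested at 100 uM (a lower number here means less inhibition, a higher number more inhibition at the concentration tested (going by the name of the read-out)), compound 1 gives 40% and compound 2 gives 40%; the step of no change at the digits printed from compound 1 to compound 2 (within the scatter) shows that exchanging thiophen-2-yl for pyridin-3-yl leaves the read-out where it was. Compound 2 therefore stands level with compound 1 at the digits shown.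

Compound 3 `C/C(=N/Nc1nc(-c2ccc(F)cc2)cs1)c1ccncc1` has not yet been measured. It differs from compound 2 as follows: pyridin-4-yl in place of pyridin-3-yl on a carbon with a double bond to nitrogen. Among the compounds with values here, only the step from compound 1 to compound 2 bears on this change, and it was flat, so a shift of the ring nitrogen within the same six-membered ring is expected to give no step beyond the scatter in this assay. For compound 3 the estimate is 40%, with range 25% to 55%, a step of no change at the digits printed from compound 2 to compound 3 (within the scatter).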

Compound 3, a percentage reported as inhibition, at one concentration (the size of the read-out at that concentration, not a potency): 40%
Compound 3: the middle estimate sits on the measured number at the digits printed; low and high end bracket the measured number.
By their numbers in this assay, from the lowest: compounds 1, 2 and 3 (each within the scatter of the next).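

Within the data shown here, with pyridin-4-yl in place of pyridin-3-yl on the carbon with a double bond to nitrogen, this assay shows no change at the digits printed from compound 2 to compound 3 (within the scatter), so this move of the ring nitrogen within the six-membered ring does not register, which the earlier compounds could not show. Against the five-membered ring, pyridin-4-yl gives no change at the digits printed from compound 1 to compound 3 (within the scatter), so thiophen-2-yl, pyridin-3-yl and pyridin-4-yl now all sit within the scatter of one another at this position. Nothing on hand offers an explanation for this flat result.

Going by these compounds, whether the flat read-out extends to a plain phenyl ring, a carboxylic acid or an amine at this position remains open. A single-concentration percentage also leaves open whether compound 1, compound 2 and compound 3 would show a matching effect at other concentrations.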